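A few compounds are considered here, and "the series" means these few. Any claim that something is new, unique, unknown or untested is made for them only; others in the source may bear on it.

Measured in a functional assay on PC-12 cells (Rattus norvegicus) for cytotoxicity, read by MTT assay, with stated times of 2 h and 24 h, tested at 1 uM; a higher number here means a stronger effect of the compound at the concentration tested, a lower number a weaker effect: compound 1 `Oc1cc(C(F)(F)F)ccc1-c1nc(-c2ccccc2O)n(-c2ccc(OC(F)(F)F)cc2)n1` gives 65.5%; compound 2 `Oc1cc(C(F)(F)F)ccc1-c1nc(-c2ccccc2O)n(-c2ccccc2Cl)n1` gives 70.1%; compound 3 `Oc1cc(C(F)(F)F)ccc1-c1nc(-c2ccccc2O)n(-c2ccc(F)cc2F)n1` gives 65.9%.

Among these three numbers, compound 3 stands second highest in this assay; it sits nearest to compound 1 and furthest from compound 2, and both gaps lie within the scatter. Compound 4 `Oc1cc(C(F)(F)F)ccc1-c1nc(-c2ccccc2O)n(-c2cc(F)cc(F)c2)n1` differs from compound 3 in one place: 3,5-difluorophenyl in place of 2,4-difluorophenyl on an aromatic nitrogen. All three measured steps exchange the group on that same aromatic nitrogen: a number 4.6 percentage points higher from compound 1 to compound 2 (within the scatter), a number 0.4 percentage points higher from compound 1 to compound 3 (within the scatter) and a number 4.2 percentage points lower from compound 2 to compound 3 (within the scatter), each within the scatter. On that basis no step beyond the scatter is expected for the move to compound 4, which is estimated at a number 0.1 percentage points higher from compound 3 to compound 4 (within the scatter). Compound 4 is therefore expected to give about 66% in this assay, within a range of 55% to 77%.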

Compound 4, a percentage reported as activity, at one concentration (the size of the read-out at that concentration, not a potency): 75.5%
Estimate against measurement, compound 4: 9.5 percentage points below; the measured number falls inside the stated range.
By their numbers in this assay, from the lowest: compounds 1, 3, 2 and 4 (each within the scatter of the next).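

Moving the two fluorines from 2,4-difluorophenyl to 3,5-difluorophenyl, with the same atoms joined differently, gives a number 9.6 percentage points higher from compound 3 to compound 4 (within the scatter) in this assay and so does not separate the two arrangements. The steps of a number 5.4 percentage points higher from compound 2 to compound 4 (within the scatter) and a number 10 percentage points higher from compound 1 to compound 4 (within the scatter) are also wider than any earlier step at this aromatic nitrogen, yet no group shown there stands apart from the others. No measured evidence bears on these numbers. The compounds shown leave open whether a phenyl carrying an amine or a carboxylic acid, or a longer alkyl chain, on this nitrogen would give a step beyond the scatter.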